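From Isopropyl to Octyl on a Shared Core

The compounds below may be only part of what the source reports. "The series", "measured", "known", "first", "only" and "open" are said of these compounds alone.

In a functional assay (trachea) with Cavia porcellus as the target (on this read-out higher numbers stand for weaker inhibition and lower numbers for stronger inhibition), two compounds with a shared core have been measured so far. Compound 1 `CCCn1nc(-c2cccnc2)c2ccccc2c1=O` carries propyl on an aromatic nitrogen and gives 3160 nM as its reading. Compound 2 `CC(C)n1nc(-c2cccnc2)c2ccccc2c1=O` carries isopropyl at that place and gives 3090 nM as its reading. These two numbers lie within the usual scatter of each other, so compound 2 stands level with compound 1 and neither can be called the better inhibitor.

The change to compound 3 `CCCCCCCCn1nc(-c2cccnc2)c2ccccc2c1=O` is octyl in place of isopropyl on an aromatic nitrogen and puts octyl in place of isopropyl on an aromatic nitrogen. Among the measured compounds shown here, the one measured step that bears on it is a 1.0-fold lower number from compound 1 to compound 2 (0.01 log units; within the scatter) and it stays within the scatter. For the measured compounds named here, that step compares two much smaller groups, and no measured compound carries a chain like octyl, so the evidence favours neither direction. No shift beyond the scatter is therefore expected in this assay although the uncertainty is wide. The expected outcome is a 1.2-fold lower number from compound 2 to compound 3 (0.09 log units; within the scatter) as a best guess. For compound 3 the estimate is 2500 nM with an expected range from 500 nM to 12000 nM at the upper end.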

Compound 3, half-maximal inhibitory concentration: 21900 nM
Compound 3: the middle estimate sits 8.8-fold (0.94 log units) below what was measured; the whole stated range lies below it.
By their numbers in this assay, from the lowest: compounds 2 and 1 (each within the scatter of the next); then compound 3.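

In this assay the group on this aromatic nitrogen does matter: octyl in place of isopropyl gives a 7.1-fold higher number from compound 2 to compound 3 (0.85 log units; beyond the scatter) and so weaker inhibition, and adding pentyl in place of hydrogen at the far end of the propyl chain gives a 6.9-fold higher number from compound 1 to compound 3 (0.84 log units; beyond the scatter) in the same direction. The earlier pair showed only that propyl and isopropyl read level with each other, so a change between these two short groups says little about what a much longer chain does at this position. Nothing measured here explains why octyl gives the weaker reading.

On these data alone, with only propyl, isopropyl and octyl at this position, it remains open where along the way from the short chains to octyl the reading begins to climb, and whether it rises gradually or in one jump, which butyl or hexyl would help to settle. As far as these compounds go, it is also open whether the loss belongs to the length of the chain as such, or whether a chain of similar length ending in an amine or a carboxylic acid would read differently.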